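This account rests on a few compounds, and the source may have more. Where it says the series, first, only, none or still open, it means among the compounds named here.

Compound 1, `CC1(Cc2cccc(C(F)(F)F)c2)CC(S(=O)(=O)c2ccc(F)cc2)=C(c2ccc(/C(N)=N/O)cc2)O1`, gives 49800 nM in an ADME assay on cells (Peritoneal macrophage, Mus musculus, strain Balb/c) for cytotoxicity, read by resazurin assay, with a stated time of 72 h; a lower number here means that less compound is tolerated, a higher number that more compound is tolerated.
Compound 2, `COc1ccc(CC2(C)CC(S(=O)(=O)c3ccc(F)cc3)=C(c3ccc(/C(N)=N/O)cc3)O2)cc1`, gives only the limit > 100000 nM.

Compound 2 stands at the limit of > 100000 nM in this assay, at which 1 of the 2 values shown sits, so for it only a limit and no number is known. Compound 3, `Cc1ccccc1CC1(C)CC(S(=O)(=O)c2ccc(F)cc2)=C(c2ccc(/C(N)=N/O)cc2)O1`, is reached from compound 2 by one change: 2-methylphenyl in place of 4-methoxyphenyl on a saturated chain carbon bound to a saturated ring carbon. Among the measured compounds shown here, the only measured step at this position is an at least 2.0-fold higher number from compound 1 to compound 2 (0.30 log units; that floor lies within the scatter), and since compound 2 gives only a limit, that step has no fixed size beyond its floor. For the measured compounds named here, neither measured compound carries 2-methylphenyl, so the change from compound 2 to compound 3 has no direct precedent, and the single step gives no direction beyond the scatter. Compound 3 is therefore expected to stay close to the tolerated level of compound 2. For compound 3 the estimate is 80000 nM, with a range from 30000 nM to 200000 nM. That estimate corresponds to an expected at least 1.2-fold lower number from compound 2 to compound 3 (0.09 log units; that floor lies within the scatter).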

Compound 3, half-maximal cytotoxic concentration: 77600 nM
The estimate for compound 3 lay 1.0-fold (0.01 log units) above the measured number, and the stated range covers the measured number.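

With compound 3, a second number at this position is available in this assay, and the comparison of two measured values gives a 1.6-fold higher number from compound 1 to compound 3 (0.19 log units; within the scatter), so 2-methylphenyl and 3-(trifluoromethyl)phenyl are not told apart here. The exchange of 4-methoxyphenyl, which brings 1 hydrogen-bond acceptor, for 2-methylphenyl, which brings none, gives an at least 1.2-fold lower number from compound 2 to compound 3 (0.11 log units; that floor lies within the scatter). This step has only a floor and no fixed size because compound 2 gives a limit and not a number: the limit of > 100000 nM in this assay, at which 1 of the 3 values shown sits.

From the compounds shown here alone, how far compound 2 really lies from compound 3 therefore stays open. So does whether a phenyl ring carrying an amine or a carboxylic acid, or a saturated cyclohexyl ring, on this saturated chain carbon would stay within the same range.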